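Swapping Bromo for Fluoro on the Aryl Hydrazone

The source may hold more compounds than are shown below. What is called first, only, known or untested is meant among the compounds shown, and "the series" means these compounds.

Three compounds share one core and differ only in the aryl group on a carbon with a double bond to nitrogen. In a functional assay on PC-3 cells (Homo sapiens) for antiproliferative activity, read by MTT assay (on this read-out lower numbers stand for stronger inhibition and higher numbers for weaker inhibition), compound 1 `Cn1c(=O)c(=O)n(C2CCCC2)c2nc(N/N=C/c3cccs3)ncc21` gives 75600 nM, compound 2 `COc1ccc(/C=N/Nc2ncc3c(n2)n(C2CCCC2)c(=O)c(=O)n3C)cc1` gives 26300 nM, and compound 3 `Cn1c(=O)c(=O)n(C2CCCC2)c2nc(N/N=C/c3ccc(F)cc3Br)ncc21` gives 9250 nM, the lowest of the three. The measured steps were a 2.9-fold lower number from compound 1 to compound 2 (0.46 log units; beyond the scatter), an 8.2-fold lower number from compound 1 to compound 3 (0.91 log units; beyond the scatter) and a 2.8-fold lower number from compound 2 to compound 3 (0.45 log units; beyond the scatter). Compound 4 `Cn1c(=O)c(=O)n(C2CCCC2)c2nc(N/N=C/c3ccc(F)cc3F)ncc21` differs from compound 3 by fluoro in place of bromo on an aromatic carbon. Every measured step replaced the whole aryl group; none exchanged one halogen for another, and they bear on this change only loosely. A step no larger than the measured ones is expected for compound 4 in this assay, more likely toward a higher number. Compound 4 is expected at 15000 nM, between 5000 nM and 45000 nM; that expectation means a 1.6-fold higher number from compound 3 to compound 4 (0.21 log units; within the scatter).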

Compound 4, half-maximal inhibitory concentration: 13200 nM
Beside the measured number, compound 4's estimate is 1.1-fold (0.06 log units) above it, within the range that was stated.
By their numbers in this assay, from the lowest: compounds 3, 4 and 2 (each within the scatter of the next, the first and the last beyond it); then compound 1.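

Fluoro in place of bromo on this aromatic carbon gives a 1.4-fold higher number from compound 3 to compound 4 (0.15 log units; within the scatter) in this assay and is the only step here that keeps the rest of the aryl group, so exchanging these two halogens leaves the number within the scatter. The 2,4-difluorophenyl group also stands within the scatter of 4-methoxyphenyl, with a 2.0-fold lower number from compound 2 to compound 4 (0.30 log units; within the scatter) while thiophen-2-yl remains clearly apart, with a 5.7-fold lower number from compound 1 to compound 4 (0.76 log units; beyond the scatter) as the printed step. Nothing measured here explains these numbers.

On these data alone, what an amine or a carboxylic acid on this aromatic carbon would do remains open.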